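From a phenoxy ether to a halogenated benzyl

The source may report more compounds than this note shows. Statements on the series, on what has been measured and on what is new or still open speak of the compounds shown alone.

Compound 1 `COc1ccccc1Oc1ccc2c(NCCCNCc3ccco3)ccnc2c1` stands at the top of the three numbers shown so far. In an ADME assay for permeability, using PAMPA, with a stated time of 30 min, at pH 7.4 (a higher number here means that the compound crosses the layer faster, a lower number that the compound crosses the layer more slowly), compound 1 gives 317 10^-6 cm/s. Compound 2 `COc1ccc(Oc2ccc3c(NCCCNCc4cccc(OC)c4O)ccnc3c2)cc1` gives 317 10^-6 cm/s in this assay, which is level with compound 1 at the digits shown and within the scatter. Compound 3 `COc1cccc(CNCCCNc2ccnc3cc(Cc4ccccc4)ccc23)c1O` gives 23 10^-6 cm/s in this assay, and the step of a 14-fold lower number from compound 2 to compound 3 (1.14 log units; beyond the scatter) is large.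

The new compound is compound 4 `Fc1ccc(Cc2ccc3c(NCCCNCc4ccco4)ccnc3c2)c(Cl)c1`. It differs from compound 1 in one place: 2-chloro-4-fluorobenzyl in place of 2-methoxyphenoxy on an aromatic carbon

For the measured compounds named here, only one measured step bears on this change. The step from compound 2 to compound 3 swaps an aryl ether for a benzyl group at the same place on the shared core, and it gave a 14-fold lower number from compound 2 to compound 3 (1.14 log units; beyond the scatter). Going by the values given here, compound 4 makes the same kind of swap on compound 1, though the entering benzyl carries a chlorine and a fluorine, for which no measured pair exists here. A lower number in this assay is therefore expected for compound 4, of roughly the size seen between compound 2 and compound 3, so that the expected step is an 11-fold lower number from compound 1 to compound 4 (1.02 log units; beyond the scatter). Compound 4 is thus estimated at 30 10^-6 cm/s in this assay, within a range from 10 10^-6 cm/s to 100 10^-6 cm/s.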

Compound 4, apparent permeability: 23 10^-6 cm/s
The estimate for compound 4 lay 1.3-fold (0.12 log units) above the measured number, within the range that was stated.
By their numbers in this assay, from the lowest: compounds 3 and 4 (each within the scatter of the next); then compounds 1 and 2 (each within the scatter of the next).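

In this assay, replacing an aryl ether with a benzyl group at this aromatic carbon now gives a large drop on two different compounds: a 14-fold lower number from compound 1 to compound 4 (1.14 log units; beyond the scatter), the same printed size as a 14-fold lower number from compound 2 to compound 3 (1.14 log units; beyond the scatter). The second drop occurs with a different group at the other end of the molecule, with the methoxy group of the departing phenoxy named at position 2 rather than 4, and with chlorine and fluorine on the entering benzyl, so the earlier step no longer stands alone. The 2-methoxyphenoxy and 2-chloro-4-fluorobenzyl groups have the same number of heavy atoms and each has one aromatic ring, but only the first has oxygen atoms and hydrogen-bond acceptors, and nothing measured here explains the drop.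

The compounds shown leave open whether the chlorine and fluorine change the number at all, a question that a 2-chlorobenzyl or 4-fluorobenzyl group on the same core would address. They also leave open how the number responds to other links between the core and the aromatic ring, such as the nitrogen link of an anilino group or a carbonyl link.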